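The compounds below may be only part of what the source reports. "The series", "measured", "known", "first", "only" and "open" are said of these compounds alone.

Of the compounds shown here, two carry a measured value so far. Compound 1 `COc1ccc(CCCCCCCCOc2ccc(C[S+]([O-])c3cccc(NS(=O)(=O)c4ccccc4)c3)nc2/C=C/C(=O)O)cc1` gives 147 nM in an assay for binding affinity to leukotriene B4 receptor 1 (Homo sapiens); a lower number here means a stronger inhibitor, a higher number a weaker inhibitor. Compound 2 `COc1ccc(CCCCCCOc2ccc(CC(O)c3cccc(C(=O)O)c3)nc2/C=C/C(=O)O)cc1` gives 165 nM in this assay. Compound 1 has the lowest of the two numbers, with compound 2 its nearest neighbour, and the two values lie within the scatter of each other. Within the data shown here, no single-point step between them is counted, since they differ in more than one place, so the two numbers can only be set side by side.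

Compound 3 `COc1ccc(CCCCCCCCOc2ccc(C[S+]([O-])c3cccc(N(C)C)c3)nc2/C=C/C(=O)O)cc1` has not yet been measured in this assay. It departs from compound 1 in one place: dimethylamino in place of (phenylsulfonyl)amino on an aromatic carbon. The group that leaves carries a six-membered aromatic ring and a hydrogen-bond donor; the group that enters has no ring and no donor. Among the measured compounds shown here, no measured step of this kind exists, so the expectation rests on the change alone. The expected step is a 2.4-fold higher number from compound 1 to compound 3 (0.38 log units; beyond the scatter), a moderate loss that still lies beyond the scatter. For compound 3 the estimated value in this assay is 350 nM, with a range from 120 nM to 1200 nM.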

Compound 3, inhibition constant: 245 nM
Beside the measured number, compound 3's estimate is 1.4-fold (0.15 log units) above it; the range from low to high includes it.
By their numbers in this assay, from the lowest: compounds 1, 2 and 3 (each within the scatter of the next).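

In this assay this position now has its first single-place step in the series: with dimethylamino in place of (phenylsulfonyl)amino on the aromatic carbon, the step is a 1.7-fold higher number from compound 1 to compound 3 (0.22 log units; within the scatter) and the pair can be read directly. In this one pair, the six-membered aromatic ring and the hydrogen-bond donor leave together and the two values stay within the scatter of each other, so neither part of the group that leaves is shown to be required at this place. No measured property of these groups is at hand to account for the result.

On these data alone, the pair removes the ring and the donor in a single change, so their separate contributions remain open; a primary amine, a methanesulfonylamino group or a benzylamino group on the same aromatic carbon would begin to pull them apart. As far as these compounds go, it also remains open whether this tolerance holds with a shorter chain in place of the eight-carbon linker, or with the sulfoxide replaced by a sulfone or a plain thioether.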